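The source may report more compounds than this note shows. Statements on the series, on what has been measured and on what is new or still open speak of the compounds shown alone.

Measured so far:
compound 1, `O=C(Nc1cccc(-c2nc(-c3ccc(NC(=O)c4cccnc4)cc3Cl)no2)c1)c1ccccc1`: 12800 nM
compound 2, `CCNC(=O)Nc1ccc(S(=O)(=O)Nc2cccc(-c3nc(-c4ccc(NC(=O)c5cccnc5)cc4Cl)no3)c2)cc1`: 3100 nM

In a functional assay on MDA-MB-231 cells (Homo sapiens) for antiproliferative activity, read by MTT assay, with a stated time of 72 h (a higher number here means a weaker inhibitor, a lower number a stronger inhibitor), compound 1 gives the highest of the two numbers; compound 2 gives a number beyond the scatter lower than that of compound 1. Compound 3, `NS(=O)(=O)Nc1ccc(NC(=O)Nc2cccc(-c3nc(-c4ccc(NC(=O)c5cccnc5)cc4Cl)no3)c2)cc1`, has not been measured. It differs from compound 1 by (4-(sulfamoylamino)phenyl)amino in place of phenyl on a carbonyl carbon. Going by the values given here, no measured pair shows a single change of this kind, so the size of the step is uncertain; a lowering beyond the scatter is expected, and the step from compound 1 to compound 3 is estimated at a 3.7-fold lower number from compound 1 to compound 3 (0.56 log units; beyond the scatter). Compound 3 is expected to give 3500 nM, between 1000 nM and 12000 nM.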

Compound 3, half-maximal inhibitory concentration: 8900 nM
Beside the measured number, compound 3's estimate is 2.5-fold (0.41 log units) below it; low and high end bracket the measured number.
By their numbers in this assay, from the lowest: compound 2; then compounds 3 and 1 (each within the scatter of the next).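

In this assay, (4-(sulfamoylamino)phenyl)amino in place of phenyl on a carbonyl carbon gives a 1.4-fold lower number from compound 1 to compound 3 (0.16 log units; within the scatter). This position therefore takes the larger group, with its added hydrogen-bond donors and acceptors, while the two numbers stay within the scatter of each other. No measurement shown here offers an explanation for this step.

The compounds shown leave open whether a methyl group or a simple amine on this carbonyl carbon would shift the number beyond the scatter. Going by these compounds, it is also open whether a carboxylic acid in place of the sulfamoylamino group would do so.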